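The source may hold more compounds than are shown below. What is called first, only, known or untested is meant among the compounds shown, and "the series" means these compounds.

Working notes on the series

Three amides of one shared core have been measured in an assay on microsomes from intestine for inhibition of acyl-CoA:cholesterol acyltransferase (Oryctolagus cuniculus); a lower number here means a stronger inhibitor, a higher number a weaker inhibitor. Compound 1, `CCCCCCCC(C)(C)C(=O)Nc1c(OC)cc(OC)cc1OC`, gives 180 nM. Compound 2, `CCCCCCCCC(C)(C)C(=O)Nc1c(OC)cc(OC)cc1OC`, gives 59 nM. Compound 3, `CCCCCCCCCCCCCCC(=O)Nc1c(OC)cc(OC)cc1OC`, gives 65 nM. Among the measured compounds shown here, the difference between compound 2 and compound 1 is methyl in place of hydrogen on a saturated chain carbon, eight bonds along the chain from a carbonyl carbon; the step of a 3.1-fold lower number from compound 1 to compound 2 (0.48 log units; beyond the scatter) is the only single-point step among the measured compounds. Compound 3 and compound 2 lie within the scatter of each other, and the difference between the core of compound 3 and the core of compound 1 is not broken down here.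

Compound 4, `CCCCCCCCCCCCCCCC(=O)Nc1c(OC)cc(OC)cc1OC`, is not yet measured. The difference between compound 4 and compound 3 is methyl in place of hydrogen on a saturated chain carbon, ten or more bonds along the chain from a carbonyl carbon. This is the same kind of change as that from compound 1 to compound 2, but the place along the chain is not identical, as the two differences themselves state, and the chain of compound 3 is unbranched rather than bearing a gem-dimethyl carbon. For the measured compounds named here, because the earlier step of a 3.1-fold lower number from compound 1 to compound 2 (0.48 log units; beyond the scatter) was modest and only one such step is known, a smaller gain is expected for compound 4, with a wide range allowed. The expected step is a 1.6-fold lower number from compound 3 to compound 4 (0.21 log units; within the scatter). Compound 4 is estimated at 40 nM, expected to fall between 15 nM and 120 nM in this assay.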

Compound 4, half-maximal inhibitory concentration: 54 nM
Compound 4: middle estimate off by 1.4-fold (0.13 log units), on the low side; measured number inside the range.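

In this assay the new step, a 1.2-fold lower number from compound 3 to compound 4 (0.08 log units; within the scatter), is a second reading of methyl in place of hydrogen on a saturated chain carbon, and the two readings do not separate: the same change on two cores in this assay, a 3.1-fold lower number (0.48 log units; beyond the scatter) from compound 1 to compound 2 and a 1.2-fold lower number (0.08 log units; within the scatter) from compound 3 to compound 4, 2.5-fold (0.40 log units) apart, within the scatter of two such steps. The change cannot be said to act differently on the two cores, but equal action is not shown either: the earlier step lies beyond the scatter, the new one lies within it, and the place along the chain is not the same in the two pairs. Two steps, one on a chain with a gem-dimethyl carbon and one on an unbranched chain, give no rule for carrying this change from one core to another, and they do not fix the size of any further such step.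

The compounds shown leave open how the number in this assay moves with a longer chain than that of compound 4, and whether a chain bearing a carboxylic acid or an amine would hold a value close to those seen here. They also leave open whether a further gem-dimethyl chain would give a step of the earlier size or one as small as the new step.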